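The source may report more compounds than this note shows. Statements on the series, on what has been measured and on what is new or still open speak of the compounds shown alone.

Measured so far:
- compound 1, `COc1ccccc1/C=c1\c(=O)[nH]/c(=C/c2cccc(Cl)c2Cl)c(=O)n1C`: 300 nM
- compound 2, `C=CCn1c(=O)/c(=C\c2cc(F)ccc2C)[nH]c(=O)/c1=C\c1ccccc1OC`: 1600 nM

Both were tested in a functional assay on BGC-823 cells (Homo sapiens) for cytotoxicity, read by CCK-8 assay, with a stated time of 72 h; on this read-out lower numbers stand for stronger inhibition and higher numbers for weaker inhibition. Of the two measured numbers, compound 2 has the higher one, and compound 1 sits well below it; that gap is beyond the usual scatter of repeated measurements, so compound 2 is the weaker of the pair in this assay.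

Compound 3, `C=CCn1c(=O)/c(=C\c2ccccc2C(F)(F)F)[nH]c(=O)/c1=C\c1ccccc1OC`, has not yet been measured. It keeps the shared core and the 2-methoxyphenyl side of compound 2 and changes only the other aryl group: 2-(trifluoromethyl)phenyl in place of 5-fluoro-2-methylphenyl on a double-bonded chain carbon bound to an aromatic carbon. Both groups are plain six-membered carbon rings carrying only fluorine and carbon substituents, with no donors or acceptors, so the swap is modest.

Going by the values given here, no measured pair shows the effect of such a change, so the step from compound 2 to compound 3 in this assay is expected to be small, a 1.1-fold lower number from compound 2 to compound 3 (0.03 log units; within the scatter), and not beyond the scatter. Compound 3 is therefore estimated at 1500 nM, within roughly 500 nM to 4500 nM.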

Compound 3, half-maximal inhibitory concentration: 5100 nM
Compound 3: middle estimate off by 3.4-fold (0.53 log units), on the low side; the measured number lies above the stated range.
By their numbers in this assay, from the lowest: compound 1; then compound 2; then compound 3.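

In this assay the aryl group on a double-bonded chain carbon bound to an aromatic carbon proves sensitive to change: 2-(trifluoromethyl)phenyl in place of 5-fluoro-2-methylphenyl gives a 3.2-fold higher number from compound 2 to compound 3 (0.50 log units; beyond the scatter) and so weaker inhibition. Both groups have one six-membered aromatic ring of carbon only, no hydrogen-bond donors or acceptors and no net charge, so these counts alone do not tell such groups apart at this place. The data shown offer no measured reason for the rise.

With only two groups compared at this place, the compounds shown leave open which part of each group matters, since the two differ in more than one substituent. They also leave open how a plain phenyl ring, or a phenyl ring carrying an amine or a carboxylic acid, would behave here.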